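The source may hold more compounds than are shown below. What is called first, only, known or untested is meant among the compounds shown, and "the series" means these compounds.

Measured compounds:
- compound 1, `C[C@H](NC(=O)c1c(CCc2ccc(F)cc2)sc2c1CC(C)(C)OC2)c1ccc(C(=O)O)cc1`; in a functional assay on CHO/Galpha16 cells for antagonist activity at prostaglandin E2 receptor EP4 subtype (Homo sapiens), read by calcium flux, with a stated time of 15 min (a lower number here means a stronger inhibitor, a higher number a weaker inhibitor), compound 1 gives 36.2 nM
- compound 2, `COc1ccc(Cc2sc3c(c2C(=O)N[C@@H](C)c2ccc(C(=O)O)cc2)CCOC3)cc1`; compound 2 gives 2.1 nM
- compound 3, `C[C@H](NC(=O)c1c(CCc2ccc(F)cc2)sc2c1CCN(C(=O)OC(C)(C)C)C2)c1ccc(C(=O)O)cc1`; compound 3 gives 315 nM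

Compound 2 has the lowest number of the three, and its gaps to compound 1 and to compound 3 both lie beyond the usual scatter, so among these measured compounds it is the strongest inhibitor.

Compound 4, `C[C@H](NC(=O)c1c(Cc2ccc(OC(F)(F)F)c(Cl)c2)sc2c1CCOC2)c1ccc(C(=O)O)cc1`, has not yet been measured in this assay. It differs from compound 2 in one place: 3-chloro-4-(trifluoromethoxy)phenyl in place of 4-methoxyphenyl on a saturated chain carbon bound to an aromatic carbon. The rest of the molecule, the shared core and the acid-bearing side chain, is the same.

For the measured compounds named here, no measured pair shows this particular exchange, so the size of its effect cannot be read from the data. Compound 2 already stands at a very low number, and the expectation is that compound 4 stays in the same region, with at most a small step toward a higher number, estimated as a 1.9-fold higher number from compound 2 to compound 4 (0.28 log units; within the scatter). For compound 4 the estimated value is 4 nM, within a range from 1 nM to 20 nM.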

Compound 4, half-maximal inhibitory concentration: 6.6 nM
Beside the measured number, compound 4's estimate is 1.7-fold (0.22 log units) below it; the measured number falls inside the stated range.
By their numbers in this assay, from the lowest: compound 2; then compound 4; then compound 1; then compound 3.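

In this assay, putting 3-chloro-4-(trifluoromethoxy)phenyl in place of 4-methoxyphenyl on a saturated chain carbon bound to an aromatic carbon gives a 3.1-fold higher number from compound 2 to compound 4 (0.50 log units; beyond the scatter) as a modest step, beyond the usual scatter. This position therefore responds to the change yet still tolerates a group of 12 heavy atoms in place of 8, since compound 4 at 6.6 nM stays well under the values of the compounds outside this pair. Nothing among the data speaks to the reason for this step.

Going by these compounds, the exchange alters the ring in two ways at once, so the separate shares of the chlorine and of the trifluoromethoxy group remain unknown. On these data alone, it also remains open how the number would move with an amine or a nitrile in place of the chlorine.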